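The compounds below may be only part of what the source reports. "The series", "measured", "known", "first", "only" and "open" are said of these compounds alone.

Measured so far in a functional assay on HeLa cells (Homo sapiens) for cytotoxicity, read by MTT assay, with a stated time of 24 h; a lower number here means a stronger inhibitor, a higher number a weaker inhibitor:
Compound 1 `COc1cc(/C=C2\CN(C)C/C(=C\c3ccc(F)cc3)C2=O)cc(OC)c1OC`: 7250 nM
Compound 2 `CN1C/C(=C\c2ccc(F)cc2)C(=O)/C(=C/c2cccc([N+](=O)[O-])c2)C1`: 6250 nM

Only these two compounds have been measured, and compound 2 at 6250 nM lies within the usual scatter of compound 1 at 7250 nM, so the two cannot be ranked. Compound 3 `CN1C/C(=C\c2cccc([N+](=O)[O-])c2)C(=O)/C(=C/c2ccc(Cl)cc2Cl)C1` has not yet been measured. It differs from compound 2 by 2,4-dichlorophenyl in place of 4-fluorophenyl on a double-bonded chain carbon bound to a double-bonded ring carbon. Among the measured compounds shown here, no measured step shows what such a change does in this assay, so the expectation is of no shift beyond the scatter, in either direction. The expected step is small, a 1.3-fold lower number from compound 2 to compound 3 (0.10 log units; within the scatter). For compound 3 the estimated value is 5000 nM, with an expected range of 2000 nM to 12000 nM.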

Compound 3, half-maximal inhibitory concentration: 8900 nM
Estimate against measurement, compound 3: 1.8-fold (0.25 log units) below, within the range that was stated.
By their numbers in this assay, from the lowest: compounds 2, 1 and 3 (each within the scatter of the next).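

In this assay, among the compounds shown here, the exchange of 4-fluorophenyl for 2,4-dichlorophenyl on a double-bonded chain carbon bound to a double-bonded ring carbon gives the first direct reading at this position: a 1.4-fold higher number from compound 2 to compound 3 (0.15 log units; within the scatter). The pair therefore shows no measurable effect of this change, even though two chlorine atoms enter where one fluorine atom leaves, so this single step gives no sign that the number depends on which of these two halogenated phenyl groups is present. No measurement at hand accounts for this result.

On these data alone, whether an aminophenyl, a carboxyphenyl or a plain phenyl group at this position would shift the number beyond the scatter remains open. As far as these compounds go, it also remains open whether the same exchange would read the same way on the core of compound 1.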